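The source may report more compounds than this note shows. Statements on the series, on what has been measured and on what is new or still open speak of the compounds shown alone.

In a functional assay on TM4 cells (Mus musculus) for cytotoxicity, read by MTT assay, with a stated time of 72 h (a higher number here means a weaker inhibitor, a lower number a stronger inhibitor), compound 1 `Nc1nc(Nc2ccccc2)sc1C(=O)c1cccnc1` gives 5500 nM and compound 2 `Nc1nc(Nc2ccccc2)sc1C(=O)c1cccc(F)c1` gives 5100 nM. Compound 3 `Nc1nc(Nc2ccc(S(N)(=O)=O)cc2)sc1C(=O)c1cccnc1` gives 13000 nM, the highest of the three numbers, and its gaps to both other compounds lie beyond the scatter. The next structure, compound 4 `Nc1nc(Nc2ccc(S(N)(=O)=O)cc2)sc1C(=O)c1cccc(F)c1`, keeps the sulfamoyl group of compound 3 and carries 3-fluorophenyl in place of pyridin-3-yl on a carbonyl carbon.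

The same exchange has been measured once, without the sulfamoyl group, as a 1.1-fold lower number from compound 1 to compound 2 (0.03 log units; within the scatter), a step within the scatter. The sulfamoyl group itself accounts for a 2.4-fold higher number from compound 1 to compound 3 (0.37 log units; beyond the scatter), a modest step, but compound 3 and compound 4 both carry it, so it does not separate them. Whether the exchange behaves alike with the sulfamoyl group present has not been tested. On the evidence of a 1.1-fold lower number from compound 1 to compound 2 (0.03 log units; within the scatter), no change beyond the scatter is expected in this assay, and the expected result is a 1.1-fold lower number from compound 3 to compound 4 (0.03 log units; within the scatter). For compound 4 the estimated value is 12000 nM, with an expected range of 6500 nM to 22000 nM.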

Compound 4, half-maximal inhibitory concentration: 4800 nM
Beside the measured number, compound 4's estimate is 2.5-fold (0.40 log units) above it; the measured number lies below the stated range.
By their numbers in this assay, from the lowest: compounds 4, 2 and 1 (each within the scatter of the next); then compound 3.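

With the sulfamoyl group present, 3-fluorophenyl in place of pyridin-3-yl on a carbonyl carbon gives a step beyond the scatter in this assay, a 2.7-fold lower number from compound 3 to compound 4 (0.43 log units; beyond the scatter), whereas the same exchange without that group stayed within the scatter. On the 3-fluorophenyl compounds, the sulfamoyl group gives only a 1.1-fold lower number from compound 2 to compound 4 (0.03 log units; within the scatter), so its modest effect appears only with pyridin-3-yl, although the two readings of the sulfamoyl change cannot be separated: the same change on two cores in this assay, a 2.4-fold higher number (0.37 log units; beyond the scatter) from compound 1 to compound 3 and a 1.1-fold lower number (0.03 log units; within the scatter) from compound 2 to compound 4, 2.5-fold (0.40 log units) apart, within the scatter of two such steps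

The exchange cannot yet be called dependent on the sulfamoyl group either, since its two readings also stay within the scatter of two such steps: the same change on two cores in this assay, a 1.1-fold lower number (0.03 log units; within the scatter) from compound 1 to compound 2 and a 2.7-fold lower number (0.43 log units; beyond the scatter) from compound 3 to compound 4, 2.5-fold (0.40 log units) apart, within the scatter of two such steps

Going by these compounds alone, only two groups are compared on the carbonyl carbon, so it remains open how a phenyl carrying an amine or a carboxylic acid would behave there. As far as these compounds go, it also remains open whether a carboxylic acid in place of the sulfamoyl group would follow the same pattern.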